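Swapping pyridin-3-yl for pyridin-4-yl in a nitrile analogue

A few compounds are considered here, and "the series" means these few. Any claim that something is new, unique, unknown or untested is made for them only; others in the source may bear on it.

Of the compounds shown here, two have so far been measured in a functional assay on HepG2 cells (Homo sapiens) for cytotoxicity, read by MTT assay, with a stated time of 24 h (a lower number here means a stronger inhibitor, a higher number a weaker inhibitor), and they give different numbers. Compound 1 (`CN1C/C(=C\c2ccc(C(F)(F)F)cc2)C(=O)/C(=C/c2cccnc2)C1`) gives 4790 nM while compound 2 (`CN1C/C(=C\c2ccc(C#N)cc2)C(=O)/C(=C/c2cccnc2)C1`) gives 12700 nM as the higher of the two, which makes it the weaker inhibitor of the pair. Going by the values given here, the only measured step is a 2.7-fold higher number from compound 1 to compound 2 (0.42 log units; beyond the scatter) when cyano replaces trifluoromethyl on an aromatic carbon, a modest change that lies beyond the scatter. The next change, to compound 3 (`CN1C/C(=C\c2ccncc2)C(=O)/C(=C/c2ccc(C#N)cc2)C1`), is pyridin-4-yl in place of pyridin-3-yl on a double-bonded chain carbon bound to a double-bonded ring carbon and keeps the same atoms, joined differently. Among the compounds with values here, the measured step concerns a different group, so it bears only indirectly: it shows that one substitution can move this number modestly, but no measured pair tests a change of pyridine. The data give no direction, so no step beyond the scatter is expected in this assay for this change. The estimated step is a 1.2-fold lower number from compound 2 to compound 3 (0.06 log units; within the scatter) with wide uncertainty. Compound 3 is expected near 11000 nM with an estimated range of 4500 nM to 27000 nM around that figure.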

Compound 3, half-maximal inhibitory concentration: 13900 nM
Beside the measured number, compound 3's estimate is 1.3-fold (0.10 log units) below it; measured number inside the range.
By their numbers in this assay, from the lowest: compound 1; then compounds 2 and 3 (each within the scatter of the next).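

Going by these compounds alone, with pyridin-4-yl in place of pyridin-3-yl on a double-bonded chain carbon bound to a double-bonded ring carbon, this assay gives the first direct reading of a pyridine change, a 1.1-fold higher number from compound 2 to compound 3 (0.04 log units; within the scatter), so compound 2 and compound 3 cannot be told apart. Within the data shown here, in this pair, the exchange of one pyridine name for the other leaves the number within the scatter, whereas the only other measured step, a 2.7-fold higher number from compound 1 to compound 2 (0.42 log units; beyond the scatter), concerns cyano and trifluoromethyl on an aromatic carbon and lies beyond it. Nothing available explains why the pyridine exchange leaves the number within the scatter.

On these data alone, what remains open is whether pyridin-2-yl, a plain phenyl or a pyridine carrying an amine or a carboxylic acid at this place would move the number beyond the scatter. Also open, as far as these compounds go, is whether the same exchange of pyridin-3-yl for pyridin-4-yl would read the same way with trifluoromethyl on the aromatic ring instead of cyano, since this single pair tests it with cyano only.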